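Swapping the amide substituent: benzylamino in a bromoindole series

A few compounds are considered here, and "the series" means these few. Any claim that something is new, unique, unknown or untested is made for them only; others in the source may bear on it.

Measured so far:
- compound 1 `C=CC(=O)N1CC(NC(=O)COc2ccc(Br)cc2C(=O)N2CC=C(c3ccccc3)C2)C1`: 1.67 h
- compound 2 `C=CC(=O)N1CC(NC(=O)Cn2cc(C(=O)N3CCc4ccccc4C3)c3cc(Br)ccc32)C1`: 1.67 h
- compound 3 `C=CC(=O)N1CC(NC(=O)Cn2cc(C(=O)N3CCc4cc(Cl)ccc4C3)c3cc(Br)ccc32)C1`: 1.67 h

All three compounds were tested in a physicochemical assay for pharmacokinetics, read by LC-MS, in phosphate buffer, at pH 7.4, in the presence of a further agent that is not named here; on this read-out higher numbers stand for a longer-lived compound and lower numbers for a shorter-lived compound. Compound 1 gives 1.67 h. Compound 2 gives 1.67 h. Compound 3 gives 1.67 h, so on this read-out compound 3 sits level with compound 1 and compound 2 at the digits shown, with no difference between them beyond the usual scatter.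

Among the measured compounds shown here, the only single-point step measured within this set runs from compound 2 to compound 3, a chloro in place of hydrogen on an aromatic carbon, and it gave no change at the digits printed from compound 2 to compound 3 (within the scatter).

Compound 4 `C=CC(=O)N1CC(NC(=O)Cn2cc(C(=O)NCc3ccccc3)c3cc(Br)ccc32)C1` has not yet been measured. It differs from compound 3 in this way: a group of 8 heavy atoms (7 carbon, 1 nitrogen; one six-membered aromatic ring of carbon only) in place of a group of 11 heavy atoms (9 carbon, 1 nitrogen, 1 chlorine; one six-membered non-aromatic ring with 1 hetero atom, one six-membered aromatic ring of carbon only), on a carbonyl carbon. For the measured compounds named here, no measured step among compounds 1 to 3 exchanges a group of this kind on the carbonyl carbon, so the one measured step is only a loose guide; it shows that a small change at the edge of the molecule left this assay unchanged.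

The expected step from compound 3 to compound 4 is therefore no change at the digits printed from compound 3 to compound 4 (within the scatter), that is, no shift beyond the scatter. For compound 4 the estimate in this assay is 1.67 h, with a range from 0.8 h to 3.5 h.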

Compound 4, half-life: 1.67 h
Compound 4: middle estimate and measured number agree at the digits printed; low and high end bracket the measured number.
By their numbers in this assay, from the lowest: compounds 1, 2, 3 and 4 (each within the scatter of the next).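

In this assay, the group on the carbonyl carbon can be changed far more than the earlier chloro step changed it: benzylamino in place of 1,2,3,4-tetrahydroisoquinolin-2-yl gave no change at the digits printed from compound 2 to compound 4 (within the scatter). The chlorinated ring group gave way to the same benzylamino with no change at the digits printed from compound 3 to compound 4 (within the scatter), so neither opening the ring nor adding the amide hydrogen moved the half-life beyond the scatter in these two pairs. No supporting data are available to explain this result.

Going by these compounds, these compounds carry only ring-bearing groups on this carbonyl carbon, so a group without a ring, such as a plain ethylamino chain, or one with a carboxylic acid or a basic amine, remains untested here. The bromine on the shared core also stays the same across compounds 2, 3 and 4, so these pairs say nothing about replacing it.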